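Loss of one chloro group on two related cores

The source may report more compounds than this note shows. Statements on the series, on what has been measured and on what is new or still open speak of the compounds shown alone.

Three compounds have numbers in a physicochemical assay for lipophilicity; on this read-out lower numbers stand for lower lipophilicity and higher numbers for higher lipophilicity. Compound 1 `O=C(Nc1ccc(Cl)cc1)Nc1ccc2c(c1)C(Nc1ccc(Cl)cc1Cl)=NS2(=O)=O` gives 4.24, the highest of the three. Compound 2 `O=C(Nc1ccc(Cl)cc1)Nc1ccc(OC2=NS(=O)(=O)c3ccccc32)cc1` gives 3.55, and compound 3 `O=C(Nc1ccccc1)Nc1ccc(OC2=NS(=O)(=O)c3ccccc32)cc1` gives 2.89. Compound 2 and compound 3 are linked by a single change, (hydrogen in place of chloro on an aromatic carbon), which made a step of a number 0.66 log units lower from compound 2 to compound 3 (beyond the scatter). The difference between the core of compound 1 and the core of compound 2 is not broken down here; their two values simply show compound 1 well above compound 2, and compound 3 further below still.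

Compound 4 `O=C(Nc1ccccc1)Nc1ccc2c(c1)C(Nc1ccc(Cl)cc1Cl)=NS2(=O)=O` has not been measured. It differs from compound 1 by hydrogen in place of chloro on an aromatic carbon, the same change seen from compound 2 to compound 3, at a place described in the same words. Among the compounds with values here, only one measured pair carries this change, so the expectation rests on that pair alone. For compound 4 the expected step is a number 0.66 log units lower from compound 1 to compound 4 (beyond the scatter), set beside the earlier one because that pair gave a number 0.66 log units lower from compound 2 to compound 3 (beyond the scatter). Compound 4 is therefore estimated at 3.58, with a range from 3.2 to 3.95.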

Compound 4, partition coefficient: 3.57
The estimate for compound 4 lay 0.01 log units above the measured number; the range from low to high includes it.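

In this assay the change from 4-chlorophenyl to phenyl gives a step on the core of compound 1 (a number 0.67 log units lower from compound 1 to compound 4 (beyond the scatter)) that is close in size to the step on the other core (a number 0.66 log units lower from compound 2 to compound 3 (beyond the scatter)), so this change carries across the two cores shown with little alteration in size. This rests on two pairs and one change, and it does not show that a step of this size would hold on a further core or for a different group at this place. Nothing measured here bears on why the two steps match in size.

On these data alone, whether groups other than chloro, such as methoxy, an amine or a carboxylic acid, on an aromatic carbon at the same place would also give matching steps on both cores remains open. The separate contribution of the two cores also stays unresolved, as compound 1 and compound 2 differ in more than one place, and so do compound 4 and compound 3.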